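This account rests on a few compounds, and the source may have more. Where it says the series, first, only, none or still open, it means among the compounds named here.

Compound 1 `C=CS(=O)(=O)N1CCN(c2ncnc3sc(-c4cccc5ncccc45)cc23)CC1`: 21000 nM
Compound 2 `C=CS(=O)(=O)N1CCN(c2ncnc3sc(-c4ccnc(Cl)c4)cc23)CC1`: 27700 nM
Compound 3 `C=CS(=O)(=O)N1CCN(c2ncnc3sc(-c4cnn(Cc5ccccc5)c4)cc23)CC1`: 19100 nM

These values all come from a functional assay on MDA-MB-231 cells (Homo sapiens) for antiproliferative activity, read by MTT assay, with a stated time of 48 h (on this read-out higher numbers stand for weaker inhibition and lower numbers for stronger inhibition), and belong to compounds with a shared core. Compound 2, at 27700 nM, cannot be separated from the other two, as its gaps to compound 1 and to compound 3 both lie within the scatter. The next compound to be tested is compound 4 `C=CS(=O)(=O)N1CCN(c2ncnc3sc(-c4c(C)noc4C)cc23)CC1`, which keeps the core and changes one group. It carries 3,5-dimethyl-1,2-oxazol-4-yl in place of 2-chloropyridin-4-yl on an aromatic carbon next to the ring sulfur (3,5-dimethyl-1,2-oxazol-4-yl in place of 2-chloropyridin-4-yl on an aromatic carbon). Among the compounds with values here, one measured step bears on this change, since it involves the same carbon: a 1.3-fold higher number from compound 1 to compound 2 (0.12 log units; within the scatter). Compound 3, with a third group at that place, gives 19100 nM in the same range. Within the data shown here, no measured compound carries the incoming group, so the evidence is indirect. Among these three compounds, changing the group has not moved the number beyond the scatter, and no step beyond the scatter is expected in this assay here either. The expected change is a 1.3-fold lower number from compound 2 to compound 4 (0.10 log units; within the scatter), an estimate that stays within the scatter. For compound 4 the estimated value is 22000 nM, with an expected range from 10000 nM to 45000 nM.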

Compound 4, half-maximal inhibitory concentration: 28200 nM
The estimate for compound 4 lay 1.3-fold (0.11 log units) below the measured number, and the stated range covers the measured number.
By their numbers in this assay, from the lowest: compounds 3, 1, 2 and 4 (each within the scatter of the next).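

In this assay, placing 3,5-dimethyl-1,2-oxazol-4-yl instead of 2-chloropyridin-4-yl on the aromatic carbon next to the ring sulfur gives a 1.0-fold higher number from compound 2 to compound 4 (0.01 log units; within the scatter) and so does not separate the two groups. Measured against the quinolin-5-yl group, the same incoming group gives a 1.3-fold higher number from compound 1 to compound 4 (0.13 log units; within the scatter) and again stays inside the usual variation between repeats. All three measured steps at this carbon now lie within the scatter, and this extends the flat picture to a group with an oxygen in its five-membered aromatic ring, with no compound shown going against it.

Going by these compounds, it remains open whether a group of another kind at this carbon, such as an amine, a carboxylic acid or a longer alkyl chain, would move the number beyond the scatter. Also open is whether any change elsewhere on the shared core would shift the numbers, as every compound shown keeps that core unchanged. Nothing available explains why these groups cannot be told apart in this read-out.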